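Chromone-triazolopyrimidine thioethers: removing the ring methyl

This account rests on a few compounds, and the source may have more. Where it says the series, first, only, none or still open, it means among the compounds named here.

Compound 3 `Cc1ccc2oc(CSc3nc4nc(C)cc(C)n4n3)cc(=O)c2c1` carries a methyl on the chromone portion and a triazolopyrimidine thioether. In a functional assay on MDA-MB-435S cells (Homo sapiens) for cytotoxicity, read by MTT assay, with a stated time of 72 h (on this read-out higher numbers stand for weaker inhibition and lower numbers for stronger inhibition), compound 3 gives > 25000 nM, which is a limit of the assay and not a number. Compound 1 `Cc1cc(C)n2nc(SCc3nnc(SCc4cc(=O)c5ccccc5o4)o3)nc2n1`, with the same thioether terminus joined through an oxadiazole spacer, gives > 25000 nM in this assay, again a limit. Compound 2 `Cc1nnc(SCc2coc3ccc(Cl)cc3c2=O)s1`, built on a different thiadiazole terminus and a chlorinated chromone, gives 2200 nM in this assay. Compound 3 thus stands at the limit shared by most of the series, as the limit of > 25000 nM in this assay, at which 2 of the 3 values shown sit, notes; only compound 2 returns a number.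

Compound 4 `Cc1cc(C)n2nc(SCc3cc(=O)c4ccccc4o3)nc2n1` differs from compound 3 by hydrogen in place of methyl on an aromatic carbon. Within the data shown here, no measured step of this kind is available; the change is small and both related compounds sit at the limit, so no step beyond the scatter is expected in either direction. Compound 4 is therefore estimated at 30000 nM (range 10000 nM to 100000 nM), a step that the limit leaves unreadable from compound 3 to compound 4 that is expected to amount to nothing, most likely reported as a limit again.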

Compound 4, half-maximal inhibitory concentration: > 25000 nM
Compound 4: a limit, no number; the forecaster's own chance of this, stated with the estimate: 80%; the middle value lies beyond the limit too.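

No step can be read from compound 3 to compound 4 in this assay, because both results are limits of the assay and not numbers: the limit of > 25000 nM in this assay, at which 3 of the 4 values shown sit.

The compounds shown leave open what hydrogen in place of methyl on an aromatic carbon does where a compound returns a number.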